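A few compounds are considered here, and "the series" means these few. Any claim that something is new, unique, unknown or untested is made for them only; others in the source may bear on it.

Measured compounds and their values:
compound 1 `COc1ccc(C2=C(c3cc(OC)c(OC)c(OC)c3)CC(O[SiH2]C(C)(C)C)C2=O)cc1[N+](=O)[O-]` — > 100 ug/mL (a limit of the assay)
compound 2 `COCOc1cc(C2=C(c3cc(OC)c(OC)c(OC)c3)C(=O)CC2O[SiH2]C(C)(C)C)ccc1OC` — 43 ug/mL
compound 3 `C=CCOc1cc(C2=C(c3cc(OC)c(OC)c(OC)c3)C(=O)C(O)C2)ccc1OC` — > 100 ug/mL (a limit of the assay)

All three were tested in an ADME assay on HT-29 cells (Homo sapiens) for cytotoxicity, read by MTT assay, with a stated time of 72 h; a higher number here means a weaker inhibitor, a lower number a stronger inhibitor. Compound 1 reaches only a limit there, > 100 ug/mL. Compound 3 likewise gives only a limit, > 100 ug/mL. For the measured compounds named here, compound 2 is therefore the one compound with an actual number, 43 ug/mL; the other two sit at the limit of > 100 ug/mL in this assay, at which 2 of the 3 values shown sit. Compound 4 `COc1cc(C2=C(c3cc(C)c(OC)c(C)c3)C(O[SiH2]C(C)(C)C)CC2=O)cc(OC)c1OC` has not yet been measured. It differs from compound 2 in one place: 4-methoxy-3,5-dimethylphenyl in place of 4-methoxy-3-(methoxymethoxy)phenyl on a double-bonded ring carbon. Going by the values given here, no step between measured compounds is available to set a size. Since two of three compounds in this set reach only the limit, the step of a 1.5-fold higher number from compound 2 to compound 4 (0.18 log units; within the scatter) is expected to be small and toward weaker inhibition, and compound 4 is estimated at 65 ug/mL, with a range from 25 ug/mL to 150 ug/mL.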

Compound 4, half-maximal inhibitory concentration: 10 ug/mL
Compound 4: middle estimate off by 6.5-fold (0.81 log units), on the high side, outside the stated range (below it).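

The aryl group on this double-bonded ring carbon is not a silent position in this assay: putting 4-methoxy-3,5-dimethylphenyl in place of 4-methoxy-3-(methoxymethoxy)phenyl gives a 4.3-fold lower number from compound 2 to compound 4 (0.63 log units; beyond the scatter), which means stronger inhibition. The methoxymethoxy group is therefore not needed for this activity, as the entering group works better with fewer oxygen atoms. Nothing measured here explains the change.

As far as these compounds go, the swap removes the methoxymethoxy group and adds two methyl groups together, so it remains open which part matters. From the compounds shown here alone, how an amine or a carboxylic acid on this phenyl ring would behave also remains open.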